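The source may report more compounds than this note shows. Statements on the series, on what has been measured and on what is new or still open speak of the compounds shown alone.

Two cores carry the same acylselenourea or isothiourea bridge: compound 1 `O=C(/N=C(/NC(=O)c1cc(-c2ccccc2)nc2ccccc12)[Se]Cc1ccccc1)c1cc(-c2ccccc2)nc2ccccc12` and compound 2 `O=C(/N=C(/NC(=O)c1cccs1)[Se]Cc1ccccc1)c1cccs1`, where the difference between the two cores is not broken down here. In an ADME assay on MCF-10A cells (Homo sapiens) for cytotoxicity, read by MTT assay, with a stated time of 72 h (a lower number here means a stronger inhibitor of growth, a higher number a weaker inhibitor of growth), compound 1 gives 45600 nM. Compound 2 reaches only the limit > 100000 nM, a limit of the assay and not a number (the limit of > 100000 nM in this assay, at which 1 of the 3 values shown sits). Compound 3 `CS/C(=N\C(=O)c1cccs1)NC(=O)c1cccs1` is compound 2 with a group of 2 heavy atoms (1 carbon, 1 sulfur; no ring) in place of a group of 8 heavy atoms (7 carbon, 1 selenium; one six-membered aromatic ring of carbon only), on a carbon with a double bond to nitrogen; compound 3 gives 55100 nM in this assay, a step of an at least 1.8-fold lower number from compound 2 to compound 3 (0.25 log units; that floor lies within the scatter). Compound 4 `CS/C(=N\C(=O)c1cc(-c2ccccc2)nc2ccccc12)NC(=O)c1cc(-c2ccccc2)nc2ccccc12` is compound 1 with a group of 2 heavy atoms (1 carbon, 1 sulfur; no ring) in place of a group of 8 heavy atoms (7 carbon, 1 selenium; one six-membered aromatic ring of carbon only), on a carbon with a double bond to nitrogen, the same change. The step from compound 1 to compound 4 in this assay is expected at a 1.3-fold lower number from compound 1 to compound 4 (0.11 log units; within the scatter), resting on the step of compound 3 from compound 2 and on compound 1 standing at 45600 nM. Compound 4 is thus estimated at 35000 nM, between 15000 nM and 80000 nM.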

Compound 4, concentration for total growth inhibition: 540 nM
Beside the measured number, compound 4's estimate is 65-fold (1.81 log units) above it; the whole stated range lies above it.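

In this assay, methylsulfanyl in place of the selenium-bearing group, on a carbon with a double bond to nitrogen, gives an 84-fold lower number from compound 1 to compound 4 (1.93 log units; beyond the scatter). This shows a large step on the core of compound 1, but whether the change carries over with the same size from one core to the other is not settled: the same change on two cores in this assay, an at least 1.8-fold lower number (0.25 log units; that floor lies within the scatter) from compound 2 to compound 3 and an 84-fold lower number (1.93 log units; beyond the scatter) from compound 1 to compound 4; the limit leaves it open whether they differ Compound 2 gives > 100000 nM, a limit of the assay and not a number.

In both steps the selenium and the aromatic ring leave together, and the compounds shown do not tell which of them matters. Also open, as far as these compounds go, is how a methylselanyl group, a benzylsulfanyl group or a longer chain on sulfur would read on these two cores.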